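The source may report more compounds than this note shows. Statements on the series, on what has been measured and on what is new or still open speak of the compounds shown alone.

In a functional assay on brain (Rattus norvegicus, strain Wistar) for inhibition (on this read-out higher numbers stand for weaker inhibition and lower numbers for stronger inhibition), compound 1 `Cc1[nH]c(=O)n(C2CCCCC2)c1-c1ccccc1` gives 47600 nM and compound 2 `COc1ccc(-c2c(C)[nH]c(=O)n2C)cc1` gives 147000 nM. Compound 3 `COc1ccc(-c2c(C)[nH]c(=O)n2C2CCCCC2)cc1` gives 20400 nM, the lowest of the three numbers and so the strongest inhibition measured so far, though still weak in absolute terms. The next compound, compound 4 `CCCCCc1ccc(-c2c(C)[nH]c(=O)n2C2CCCCC2)cc1`, has pentyl in place of methoxy on an aromatic carbon.

Within the data shown here, two measured steps bear on this change. Methoxy in place of hydrogen on that same carbon gave a 2.3-fold lower number from compound 1 to compound 3 (0.37 log units; beyond the scatter), a modest step. Cyclohexyl in place of methyl on an aromatic nitrogen gave a 7.2-fold lower number from compound 2 to compound 3 (0.86 log units; beyond the scatter), also modest, although at a different place. In both steps, the larger group came with the lower number. Among the measured compounds shown here, no alkyl chain has yet been measured on this carbon, so the expectation is loose: a modest further move towards a lower number in this assay. The expected step is a 2.3-fold lower number from compound 3 to compound 4 (0.36 log units; beyond the scatter). Compound 4 is estimated at 9000 nM, with an expected range from 2500 nM to 30000 nM.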

Compound 4, half-maximal inhibitory concentration: 10600 nM
For compound 4 the middle estimate is 1.2-fold (0.07 log units) below the measured one; low and high end bracket the measured number.
By their numbers in this assay, from the lowest: compounds 4 and 3 (each within the scatter of the next); then compound 1; then compound 2.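

In this assay, pentyl in place of methoxy gives a 1.9-fold lower number from compound 3 to compound 4 (0.28 log units; within the scatter), so compounds 3 and 4 cannot be told apart. On this aromatic carbon, a five-carbon chain with no hydrogen-bond acceptor therefore serves as well as methoxy, which carries one, so in this pair the acceptor is not needed to keep the number at this level. Compared with hydrogen on the same carbon, pentyl gives a 4.5-fold lower number from compound 1 to compound 4 (0.65 log units; beyond the scatter), which shows that a group here can matter even though these two groups cannot be separated, and nothing available explains this result.

The compounds shown leave open whether a longer chain such as octyl, an amine or a carboxylic acid on this carbon would keep the number at this level or shift it. They also leave open whether pentyl would behave the same way with methyl in place of cyclohexyl on the aromatic nitrogen.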